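This account rests on a few compounds, and the source may have more. Where it says the series, first, only, none or still open, it means among the compounds named here.

Compound 1 `C=CCCCn1c(Cc2cc(OC)c(OC)c(OC)c2)nc2c(N)nc(F)nc21` is tested in a functional assay on MCF7 cells (Homo sapiens) for antiproliferative activity (on this read-out lower numbers stand for stronger inhibition and higher numbers for weaker inhibition), where compound 1 gives 44700 nM, the highest of the two numbers recorded. Among the compounds with values here, compound 2 `CCCCn1c(Cc2c(Br)c(OC)c(OC)c(OC)c2Br)nc2c(N)ncnc21` gives 30200 nM in this assay, and that number lies within the scatter of the one for compound 1, so the two cannot be told apart. Compound 3 `CCCCCn1c(Cc2cc(OC)c(OC)c(OC)c2)nc2c(N)nc(F)nc21` has not yet been measured. It differs from compound 1 in one place: ethyl in place of vinyl on a saturated chain carbon, three bonds along the chain from an aromatic nitrogen. Within the data shown here, no measured pair shows this change, and a step of at most the size of the scatter, in either direction, is expected from compound 1 to compound 3, a 1.2-fold lower number from compound 1 to compound 3 (0.07 log units; within the scatter). Compound 3 is therefore estimated at 38000 nM, with a range from 12000 nM to 120000 nM.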

Compound 3, half-maximal inhibitory concentration: 36300 nM
Beside the measured number, compound 3's estimate is 1.0-fold (0.02 log units) above it, within the range that was stated.
By their numbers in this assay, from the lowest: compounds 2, 3 and 1 (each within the scatter of the next).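

In this assay, ethyl in place of vinyl on this chain carbon gives a 1.2-fold lower number from compound 1 to compound 3 (0.09 log units; within the scatter) and so leaves pent-4-en-1-yl and pentyl indistinguishable on the core of compound 1. This first single-place pair shows that, here, removing the double bond from the chain end produces no difference beyond the scatter. No evidence in hand bears on this result. Still open, on these data alone, is whether a longer chain, or an amine or carboxylic acid at this place, would move the number beyond the scatter.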